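Removing the phenoxy group from compound 2

The source may report more compounds than this note shows. Statements on the series, on what has been measured and on what is new or still open speak of the compounds shown alone.

compound 1 `COc1ccc(C2C(O)C(=O)N2c2cc(OC)c(OC)c(OC)c2)cc1` gives 13 nM
compound 2 `CCSc1ccc(C2C(Oc3ccccc3)C(=O)N2c2cc(OC)c(OC)c(OC)c2)cc1` gives 508 nM
compound 3 `C=CC1C(=O)N(c2cc(OC)c(OC)c(OC)c2)C1c1ccc(SC)cc1` gives 61 nM

In a functional assay on HL-60 cells (Homo sapiens) for inhibition, read by resazurin assay, with a stated time of 72 h (a higher number here means a weaker inhibitor, a lower number a stronger inhibitor), compound 2 has the highest of the three numbers and is the weakest inhibitor so far. It lies beyond the usual scatter from both other compounds, with compound 3 the nearer and compound 1 the further.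

The next compound is compound 4 `CCSc1ccc(C2CC(=O)N2c2cc(OC)c(OC)c(OC)c2)cc1`, which has hydrogen in place of phenoxy on a saturated ring carbon is the full count of the change.

For the measured compounds named here, no measured pair isolates this change. Compound 2 (508 nM) carries a phenoxy group. Compound 1 (13 nM) and compound 3 (61 nM) carry none and both read lower than compound 2, but both also differ from compound 2 elsewhere. A lower number in this assay, beyond the scatter, is therefore expected, though this rests on indirect evidence.

The estimated change is a 4.2-fold lower number from compound 2 to compound 4 (0.63 log units; beyond the scatter) in size.

For compound 4 the expected value is 120 nM (estimated range 30 nM to 450 nM).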

Compound 4, half-maximal inhibitory concentration: 204 nM
Beside the measured number, compound 4's estimate is 1.7-fold (0.23 log units) below it, within the range that was stated.
By their numbers in this assay, from the lowest: compound 1; then compound 3; then compound 4; then compound 2.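

In this assay, for the compounds shown here, this is the first step that isolates one place: hydrogen in place of phenoxy on a saturated ring carbon gives a 2.5-fold lower number from compound 2 to compound 4 (0.40 log units; beyond the scatter) and counts as modest. It confirms, from a direct comparison, that the phenoxy-bearing compound reads higher at this position, with the 4-(ethylsulfanyl)phenyl group and the rest of the structure held the same. The data offer no measurement that explains this step.

On these data alone, whether a group such as an amine or a carboxylic acid on this ring carbon would read lower or higher than hydrogen remains open. Compound 1 and compound 3 carry other groups here but also differ elsewhere, so their steps to compound 4 cannot be read.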